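A few compounds are considered here, and "the series" means these few. Any claim that something is new, unique, unknown or untested is made for them only; others in the source may bear on it.

Compound 1 `COc1cccc(NC2=CC(=O)c3nc4n(c3C2=O)[C@H]2OC[C@@H](O)[C@H]2OC4)c1` — in a functional assay on MCF7 cells (Homo sapiens) for inhibition, read by sulforhodamine B assay (a higher number here means a weaker inhibitor, a lower number a stronger inhibitor), compound 1 gives > 4000 nM, which is a limit of the assay rather than a number.
Compound 2 `COc1ccccc1NC1=CC(=O)c2c(nc3n2[C@H]2OC[C@@H](O)[C@H]2OC3)C1=O` — in this assay compound 2 gives 6580 nM.
Compound 3 `O=C1C(Nc2ccc(Br)cc2)=CC(=O)c2c1nc1n2[C@H]2OC[C@@H](O)[C@H]2OC1` — in this assay compound 3 gives 4330 nM.

All three compounds share one core and differ only in the substituted phenyl group on the amine nitrogen. For the measured compounds named here, compound 1 stands at the limit of > 4000 nM in this assay, at which 1 of the 3 values shown sits, so its exact place among the three is not known; compound 2 and compound 3 both sit in the weak range, and the only measured step, a 1.5-fold lower number from compound 2 to compound 3 (0.18 log units; within the scatter), is within the scatter. Compound 4 `O=C1C=C(Nc2cccc(F)c2)C(=O)c2c1nc1n2[C@H]2OC[C@@H](O)[C@H]2OC1` differs from compound 1 by fluoro in place of methoxy on an aromatic carbon. Going by the values given here, no measured step swaps these two groups, and the one measured change of the phenyl group left the number essentially unchanged. Compound 4 is therefore expected to remain a weak inhibitor, with the step that the limit leaves unreadable from compound 1 to compound 4 not expected to go beyond the scatter. Compound 4 is estimated at 5500 nM, with a likely range from 2500 nM to 13000 nM.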

Compound 4, half-maximal inhibitory concentration: 5500 nM
Beside the measured number, compound 4's estimate shows no gap at the digits printed, and the stated range covers the measured number.
By their numbers in this assay, from the lowest: compounds 3, 4 and 2 (each within the scatter of the next).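

The step from compound 1 to compound 4 cannot be read, because the value of compound 1 is a limit and not a number: the limit of > 4000 nM in this assay, at which 1 of the 4 values shown sits.

The compounds shown leave open whether fluoro in place of methoxy changes the number at all, and whether any change to the phenyl group moves it beyond the scatter.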